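The source may report more compounds than this note shows. Statements on the series, on what has been measured and on what is new or still open speak of the compounds shown alone.

Of the compounds shown here, two that share the same core have been measured. Compound 1 `C=C1C(=O)O[C@@H](c2ccccc2)[C@H]1C` gives 14% in a functional assay on MIA PaCa-2 cells (Homo sapiens) for cytotoxicity, read by MTT assay, with a stated time of 72 h, tested at 10 uM; on this read-out lower numbers stand for a stronger effect and higher numbers for a weaker effect at the one concentration tested. Compound 2 `C=C1C(=O)O[C@H](c2ccc(OC)cc2)[C@H]1c1ccccc1` gives 0% in this assay, the lower of the two numbers, with compound 1 standing higher by an amount beyond the scatter. The compound still to be measured is compound 3 `C=C1C(=O)O[C@H](c2ccc(C(F)(F)F)cc2)[C@H]1c1ccccc1`, which differs from compound 2 by trifluoromethyl in place of methoxy on an aromatic carbon. Among the compounds with values here, no pair that differs in one place has been measured, so nothing shows how this change acts. Compound 3 is therefore expected to sit close to compound 2, with an expected step of a number 6 percentage points higher from compound 2 to compound 3 (within the scatter) that should stay within the scatter. Compound 3 is estimated at 6%, expected between 0% and 28%.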

Compound 3, a percentage reported as activity, at one concentration (the size of the read-out at that concentration, not a potency): 5%
For compound 3 the middle estimate is 1 percentage points above the measured one; low and high end bracket the measured number.
By their numbers in this assay, from the lowest: compounds 2, 3 and 1 (each within the scatter of the next, the first and the last beyond it).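

In this assay, the step for trifluoromethyl in place of methoxy on an aromatic carbon, para to a large group, is a number 5 percentage points higher from compound 2 to compound 3 (within the scatter). This first pair differing in one place shows that the two groups cannot be told apart at this position at the one concentration tested. Nothing measured here bears on what lies behind this result.

On these data alone, whether an amine, a carboxylic acid or a longer chain at this position would read the same remains open. Also open, as far as these compounds go, is whether compounds with these two groups would differ across a range of concentrations.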